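Sulfur-chain terminus variation in a pyridylbenzylamine series

The compounds below may be only part of what the source reports. "The series", "measured", "known", "first", "only" and "open" are said of these compounds alone.

Measured compounds:
compound 1, `CC(C)c1n[nH]c2c(NCc3ccc(-c4ccccn4)cc3)nc(SCC(O)C(F)(F)F)nc12`, 690 nM
compound 2, `CC(C)c1n[nH]c2c(NCc3ccc(-c4ccccn4)cc3)nc(SCC(N)CN)nc12`, 480 nM
compound 3, `CNCCSc1nc(NCc2ccc(-c3ccccn3)cc2)c2[nH]nc(C(C)C)c2n1`, 56 nM

In a functional assay on HT cells (Homo sapiens) for antiproliferative activity, read by fluorescence, with a stated time of 72 h (on this read-out lower numbers stand for stronger inhibition of growth and higher numbers for weaker inhibition of growth), compound 3 gives the lowest number of the three; its separation from compound 2 and from compound 1 is beyond the scatter, so it is the strongest inhibitor here. Compound 4, `CC(C)c1n[nH]c2c(NCc3ccc(-c4ccccn4)cc3)nc(SCCn3ccnc3)nc12`, differs from compound 3 by 1H-imidazol-1-yl in place of methylamino on a saturated chain carbon, two bonds along the chain from a sulfur. The steps bearing on this position are an 8.6-fold lower number from compound 2 to compound 3 (0.93 log units; beyond the scatter) and a 12-fold lower number from compound 1 to compound 3 (1.09 log units; beyond the scatter), both sizeable, whereas a 1.4-fold lower number from compound 1 to compound 2 (0.16 log units; within the scatter). The chain end thus shifts the read-out strongly, and the methylamino group that marks the lowest number is given up. A move toward higher numbers is expected, around a 3.6-fold higher number from compound 3 to compound 4 (0.55 log units; beyond the scatter). Compound 4 is estimated at 200 nM, range 60 nM to 650 nM.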

Compound 4, concentration for 50% growth inhibition: 155 nM
Compound 4: the middle estimate sits 1.3-fold (0.11 log units) above what was measured; the measured number falls inside the stated range.
By their numbers in this assay, from the lowest: compound 3; then compound 4; then compounds 2 and 1 (each within the scatter of the next).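

In this assay, 1H-imidazol-1-yl in place of methylamino gives a 2.8-fold higher number from compound 3 to compound 4 (0.44 log units; beyond the scatter), so the chain end accepts an aromatic ring at a modest cost. The imidazole end, with no hydrogen-bond donor, still improves on the other two chain ends, with a 3.1-fold lower number from compound 2 to compound 4 (0.49 log units; beyond the scatter) and a 4.5-fold lower number from compound 1 to compound 4 (0.65 log units; beyond the scatter), so a donor at this end is not needed for a number lower than those of compound 2 and compound 1. No supporting data explain these shifts.

Open, going by these compounds, is whether a dimethylamino end, a piperazine end or a longer chain carrying methylamino would match compound 3.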